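A Halogen Swap on the Benzyl Arm of Compound 1

This account rests on a few compounds, and the source may have more. Where it says the series, first, only, none or still open, it means among the compounds named here.

Compound 1 `COc1ccc(N2C(=O)N(Cc3c(F)cc(F)cc3OC)c3ccccc3S2(=O)=O)cc1OC` — 63.1 nM
Compound 2 `COc1cc(F)c(CN2C(=O)N(c3cc(OC)nc(OC)c3)S(=O)(=O)c3ccccc32)c(F)c1` — 1 nM
Compound 3 `COc1cc(N2C(=O)N(Cc3c(F)cc(F)cc3F)c3ccccc3S2(=O)=O)ccn1` — 398 nM

In an assay on isolated protein for displacement of a labelled ligand from Orexin/Hypocretin receptor type 1 (Homo sapiens), with a stated time of 90 min (a higher number here means a weaker inhibitor, a lower number a stronger inhibitor), compound 1 gives 63.1 nM, the second highest of the three numbers shown. Compound 3 gives 398 nM, a higher number that lies beyond the scatter, and compound 2 gives 1 nM, a much lower number, also beyond the scatter. Compound 4 `COc1ccc(N2C(=O)N(Cc3c(F)cccc3Cl)c3ccccc3S2(=O)=O)cc1OC` has not yet been measured. It differs from compound 1 in one place: 2-chloro-6-fluorophenyl in place of 2,4-difluoro-6-methoxyphenyl on a saturated chain carbon bound to an amide-type nitrogen in a ring. Within the data shown here, no pair of measured compounds isolates this change, so the expectation rests on compound 1 alone. The estimate for compound 4 means a step of a 1.3-fold lower number from compound 1 to compound 4 (0.10 log units; within the scatter), expected to stay within the usual scatter with no clear direction. Compound 4 is therefore estimated at 50 nM, with a likely range from 15 nM to 200 nM.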

Compound 4, inhibition constant: 7.94 nM
For compound 4 the middle estimate is 6.3-fold (0.80 log units) above the measured one, outside the stated range (below it).
By their numbers in this assay, from the lowest: compound 2; then compound 4; then compound 1; then compound 3.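

In this assay, the group on a saturated chain carbon bound to an amide-type nitrogen in a ring proves sensitive to substitution: 2-chloro-6-fluorophenyl in place of 2,4-difluoro-6-methoxyphenyl gives a 7.9-fold lower number from compound 1 to compound 4 (0.90 log units; beyond the scatter). The entering group has fewer heavy atoms and no hydrogen-bond acceptor, so a stronger inhibitor does not depend on keeping the methoxy oxygen here. No measurement shown explains the difference.

Among these compounds, the single swap changes several substituents at once, leaving their separate contributions unresolved. On these data alone, it remains open whether bromine or methyl in place of the chlorine would give a similar number.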